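A 3,4-dimethylphenyl group on compound 2

A few compounds are considered here, and "the series" means these few. Any claim that something is new, unique, unknown or untested is made for them only; others in the source may bear on it.

Measured so far in a functional assay on MDA-MB-231 cells (Homo sapiens) for cytotoxicity, read by MTT assay, with a stated time of 48 h; a higher number here means a weaker inhibitor, a lower number a stronger inhibitor
Compound 1 `O=C(NCCCCC(c1ccc(F)cc1)c1ccc(F)cc1)Nc1cccc([N+](=O)[O-])c1` gives 3790 nM
Compound 2 `Nc1cc(NC(=O)NCCCCC(c2ccc(F)cc2)c2ccc(F)cc2)ccc1Cl` gives 9240 nM

Of these two, compound 2 gives 9240 nM as the higher number. Compound 3 `Cc1ccc(NC(=O)NCCCCC(c2ccc(F)cc2)c2ccc(F)cc2)cc1C` differs from it in one place, and 3,4-dimethylphenyl in place of 3-amino-4-chlorophenyl on an amide-type nitrogen is the whole change, 3,4-dimethylphenyl in place of 3-amino-4-chlorophenyl on an amide-type nitrogen. Among the measured compounds shown here, the one measured step at that place is the modest 2.4-fold higher number from compound 1 to compound 2 (0.39 log units; beyond the scatter) in which 3-amino-4-chlorophenyl took the place of 3-nitrophenyl. For the measured compounds named here, no measured compound carries 3,4-dimethylphenyl, so a step of similar modest size is expected in this assay with only a slight lean toward a lower number, as compound 1 gives 3790 nM with a different group at that place. The expected step is a 1.7-fold lower number from compound 2 to compound 3 (0.23 log units; within the scatter) by this estimate. Compound 3 is estimated at 5500 nM with an expected range of 2000 nM to 15000 nM for the measurement.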

Compound 3, half-maximal inhibitory concentration: > 20000 nM
Compound 3: only a limit was reported; the forecaster's own chance of this, stated with the estimate: 10%; at least 3.6-fold (0.56 log units) between middle value and limit.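

In this assay, among the compounds shown here, the group on the amide-type nitrogen can do more than the earlier pair showed, where the only step was a 2.4-fold higher number from compound 1 to compound 2 (0.39 log units; beyond the scatter). Compound 3 gives only a limit of the assay and not a number: the limit of > 20000 nM in this assay, at which 1 of the 3 values shown sits.

Set against that limit, the change to 3,4-dimethylphenyl gives an at least 2.1-fold higher number from compound 2 to compound 3 (0.33 log units; beyond the scatter) and an at least 5.2-fold higher number from compound 1 to compound 3 (0.72 log units; beyond the scatter). Among the three compounds, the two whose groups carry nitrogen give measured numbers, while the all-carbon 3,4-dimethylphenyl group, with no hydrogen-bond donors or acceptors, reaches the limit, and no compound shown goes against this.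

How far compound 3 lies past its limit cannot be read. The compounds shown also leave open how a phenyl ring carrying a single methyl group, a single chlorine or a single amino group would compare.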